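Extending the Urea Side Chain of a Histamine H2 Agonist

The compounds below may be only part of what the source reports. "The series", "measured", "known", "first", "only" and "open" are said of these compounds alone.

Compound 1 `CCCNC(=O)/N=C(\N)NCCCc1sc(N)nc1C` is a guanidine-urea bearing the shared aminothiazole core. Within the data shown here, in a functional assay on HEK293T cells for agonist activity at histamine H2 receptor (Homo sapiens), read by beta-arrestin recruitment (a higher number here means a larger maximal response, a lower number a smaller maximal response), compound 1 gives 0.32, the lowest of the two numbers known here. Its nearest neighbour is compound 2 `Cc1nc(N)sc1CCCN/C(N)=N/C(=O)NCc1ccccc1`, which in this assay gives 0.33; the step a number 0.010 higher from compound 1 to compound 2 (within the scatter) is within the scatter, so the two compounds cannot be told apart on maximal response.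

Compound 3 `Cc1nc(N)sc1CCCN/C(N)=N/C(=O)NCC(C)CCCc1ccccc1` is the unmeasured compound. It differs from compound 1 as follows: 3-phenylpropyl in place of hydrogen on a saturated chain carbon bound to two saturated chain carbons. Among the measured compounds shown here, the only measured step, from compound 1 to compound 2, concerns a saturated chain carbon bound to an amide-type nitrogen, not a saturated chain carbon bound to two saturated chain carbons, so it bears on the new change only in showing that adding a phenyl to this side of the molecule left the response unchanged. For the measured compounds named here, no step that exactly matches the insertion of 3-phenylpropyl exists. The account therefore expects no step beyond the scatter in this assay, with a number 0.010 higher from compound 1 to compound 3 (within the scatter) as the estimated change. For compound 3 the estimated maximal response in this assay is 0.33, with a range from 0.2 to 0.48.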

Compound 3, intrinsic activity: the largest response reached, as a fraction of the reference agonist's: 0.14
For compound 3 the middle estimate is 0.19 above the measured one, and the stated range ends above it.
By their numbers in this assay, from the lowest: compound 3; then compounds 1 and 2 (each within the scatter of the next).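

In this assay, 3-phenylpropyl on a saturated chain carbon bound to two saturated chain carbons gives a maximal response a number 0.18 lower from compound 1 to compound 3 (beyond the scatter), whereas phenyl in place of ethyl on a saturated chain carbon bound to an amide-type nitrogen had given only a number 0.010 higher from compound 1 to compound 2 (within the scatter). Compound 3 thus shows what compound 2 could not: the maximal response on this side of the molecule does not stay the same with every added group, and a substituent at this position can take it beyond the scatter. Nothing available here bears on the reason for this fall in maximal response.

The compounds shown leave open whether the lower response goes with the aromatic ring at the end of 3-phenylpropyl or with the carbon chain that carries it, as the two enter together in compound 3. A cyclohexyl ring in place of that phenyl ring, or a plain butyl chain at the same saturated chain carbon, would pull these two parts of the change apart.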